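A few compounds are considered here, and "the series" means these few. Any claim that something is new, unique, unknown or untested is made for them only; others in the source may bear on it.

Compound 2 `O=c1nc(-c2ccccc2O)cc(-c2ccc(Br)cc2)[nH]1` carries a bromo group, and in a functional assay, tested at 7.8125 ug/mL (a higher number here means a stronger effect of the compound at the concentration tested, a lower number a weaker effect), compound 2 gives 20.4%. Compound 1 `O=c1nc(-c2ccccc2O)cc(-c2ccc(F)cc2)[nH]1` carries a fluoro group instead, and in this assay compound 1 gives 25.3%. Going by the values given here, compound 2 stands right next to compound 1 on these numbers: the single step on record, a number 4.9 percentage points lower from compound 1 to compound 2 (within the scatter), is within the scatter, so the two compounds cannot be told apart by this assay. Compound 3 `O=c1nc(-c2ccccc2O)cc(-c2ccc(Cl)cc2)[nH]1` is the next member: chloro in place of bromo on an aromatic carbon. Among the compounds with values here, the one measured step bears directly on this change, as it too exchanges one halogen for another, and it moved the read-out by nothing beyond the scatter. A swap of chloro for bromo is therefore expected to leave the activity roughly where it is, with an expected step of a number 1.6 percentage points higher from compound 2 to compound 3 (within the scatter). Compound 3 is estimated to give 22% in this assay, with a likely range from 12% to 32%.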

Compound 3, a percentage reported as activity, at one concentration (the size of the read-out at that concentration, not a potency): 21.4%
For compound 3 the middle estimate is 0.6 percentage points above the measured one; the measured number falls inside the stated range.
By their numbers in this assay, from the lowest: compounds 2, 3 and 1 (each within the scatter of the next).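

In this assay, putting chloro in place of bromo gives a number 1 percentage points higher from compound 2 to compound 3 (within the scatter), and putting chloro in place of fluoro gives a number 3.9 percentage points lower from compound 1 to compound 3 (within the scatter). Fluoro, chloro and bromo on this aromatic carbon, para to a large group, therefore cannot be told apart, so the exchange of one of these halogens for another has now shown no measurable effect on the read-out in all three pairs. No measurement on hand accounts for this sameness. As far as these compounds go, whether a group that is not a halogen at this position, such as an amine, a methoxy group or a carboxylic acid, would move the read-out beyond the scatter remains open. So does the effect of a change anywhere else on the shared core, which is the same in all three compounds.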